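From thiophen-2-yl to phenyl on a saturated chain carbon

A few compounds are considered here, and "the series" means these few. Any claim that something is new, unique, unknown or untested is made for them only; others in the source may bear on it.

Compound 1 `Cc1ccc2c(C(CC(F)(F)F)c3ccccc3)c(-c3ccccc3)[nH]c2c1` gives 0.47 h
Compound 2 `FC(F)(F)CC(c1ccco1)c1c(-c2ccccc2)[nH]c2cc(Cl)ccc12` gives 0.772 h
Compound 3 `FC(F)(F)CC(c1cccs1)c1c(-c2ccccc2)[nH]c2cc(Cl)ccc12` gives 0.905 h

These half-lives come from an ADME assay on microsomes from liver (Rattus norvegicus) for metabolic stability, read by LC-MS, using NADPH, tested at 3 uM; on this read-out higher numbers stand for a longer-lived compound and lower numbers for a shorter-lived compound. Compound 3 (0.905 h) lies within the usual scatter of both other compounds, so the three cannot be ranked. Compound 4 `FC(F)(F)CC(c1ccccc1)c1c(-c2ccccc2)[nH]c2cc(Cl)ccc12` is still unmeasured. It carries phenyl in place of thiophen-2-yl on a saturated chain carbon bound to an aromatic carbon and a saturated chain carbon. Going by the values given here, the one measured ring swap at this place is a 1.2-fold higher number from compound 2 to compound 3 (0.07 log units; within the scatter), which is small. Compound 1 (0.47 h) already holds phenyl there but differs elsewhere in the core. No step beyond the scatter is therefore expected, and the expected change is a 1.3-fold lower number from compound 3 to compound 4 (0.11 log units; within the scatter). Compound 4 is estimated at 0.7 h (expected range 0.4 h to 1.2 h) .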

Compound 4, half-life: 1.3 h
Compound 4: the middle estimate sits 1.9-fold (0.27 log units) below what was measured; measured number above the stated range.
By their numbers in this assay, from the lowest: compounds 1, 2, 3 and 4 (each within the scatter of the next, the first and the last beyond it).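

In this assay, swapping the ring on the saturated chain carbon stays within the scatter, whether phenyl replaces thiophen-2-yl (a 1.4-fold higher number from compound 3 to compound 4 (0.16 log units; within the scatter)) or furan-2-yl (a 1.7-fold higher number from compound 2 to compound 4 (0.23 log units; within the scatter)). Going by these compounds alone, the only step beyond the scatter comes from the other position, an aromatic carbon, where chloro replaces methyl (a 2.8-fold higher number from compound 1 to compound 4 (0.44 log units; beyond the scatter)). No supporting measurement is available to explain these results. Still open, from the compounds shown here alone, is how a non-aromatic group, such as cyclohexyl or an amine, would behave on the chain carbon, and how a methoxy group or nitrile would compare with chloro on the aromatic carbon.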